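Swapping the Anilide Ring from Compound 1 to Compound 3

This account rests on a few compounds, and the source may have more. Where it says the series, first, only, none or still open, it means among the compounds named here.

Of the compounds shown here, two sharing one core have been measured so far. Compound 1 `O=C(CN1CCN(c2nnc(Cc3ccncc3)c3ccccc23)CC1)Nc1ccc(F)c(Cl)c1` gives 880 nM in a functional assay on HT-29 cells (Homo sapiens) for cytotoxicity, read by MTT assay, with a stated time of 72 h (a lower number here means a stronger inhibitor, a higher number a weaker inhibitor), the lower of the two numbers. Compound 2 `O=C(CN1CCN(c2nnc(Cc3ccccc3)c3ccccc23)CC1)Nc1ccc(F)c(C(F)(F)F)c1` gives 4590 nM in this assay, a gap beyond the usual scatter, although these two compounds differ in more than one place, so no single change explains it. Compound 3 `Cc1ccc(F)cc1NC(=O)CN1CCN(c2nnc(Cc3ccncc3)c3ccccc23)CC1` differs from compound 1 in one place: 5-fluoro-2-methylphenyl in place of 3-chloro-4-fluorophenyl on an amide-type nitrogen. Within the data shown here, with no measured single-point step available as a guide, the step of a 2.3-fold higher number from compound 1 to compound 3 (0.36 log units; beyond the scatter) is expected to be modest and toward a weaker inhibitor. Compound 3 is estimated at 2000 nM, in the range 600 nM to 6500 nM.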

Compound 3, half-maximal inhibitory concentration: 470 nM
The estimate for compound 3 lay 4.3-fold (0.63 log units) above the measured number; the measured number lies below the stated range.
By their numbers in this assay, from the lowest: compounds 3 and 1 (each within the scatter of the next); then compound 2.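

Among these compounds, this is the first comparison that changes only one place, and in this assay the step is small: a 1.9-fold lower number from compound 1 to compound 3 (0.27 log units; within the scatter). The anilide ring can therefore lose its chlorine and gain a methyl, with its fluorine in a different place, without the number leaving the usual scatter. No measurement of any property of these groups comes with this result.

Steps involving compound 2 cannot be read, since it differs from compound 1 and compound 3 in more than one place. From the compounds shown here alone, whether a larger group on this ring, such as an amine or a carboxylic acid, would keep the number in this range stays open.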